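A few compounds are considered here, and "the series" means these few. Any claim that something is new, unique, unknown or untested is made for them only; others in the source may bear on it.

Compound 1 `Cc1ccc(C(=O)Nc2ccc(-c3nc4c([nH]3)c(=O)n(C)c(=O)n4C)cc2)cc1` and compound 2 `COc1ccc(C(=O)Nc2ccc(-c3nc4c([nH]3)c(=O)n(C)c(=O)n4C)cc2)cc1` share one core. In an assay for inhibition of Amine oxidase [flavin-containing] B (Mus musculus), read by fluorescence, with a stated time of 30 min, in the presence of a further agent that is not named here (on this read-out lower numbers stand for stronger inhibition and higher numbers for weaker inhibition), compound 1 gives 2770 nM, and compound 2 gives 3970 nM. The change between them is methoxy in place of methyl on an aromatic carbon, and it made the step of a 1.4-fold higher number from compound 1 to compound 2 (0.16 log units; within the scatter). Compound 3 `Cc1ccc(C(=O)Nc2cccc(-c3nc4c(c(=O)n(C)c(=O)n4C)n3C)c2)cc1` carries a different core; the difference between the two cores is not broken down here. In this assay compound 3 gives 3560 nM. Compound 4 `COc1ccc(C(=O)Nc2cccc(-c3nc4c(c(=O)n(C)c(=O)n4C)n3C)c2)cc1`, not yet measured, differs from compound 3 by methoxy in place of methyl on an aromatic carbon; the place is described in the same words as for compound 1 and compound 2, so this is the same change on the second core. The step for compound 4 is expected to be a 1.4-fold higher number from compound 3 to compound 4 (0.15 log units; within the scatter), close to the earlier one, because the same change gave a 1.4-fold higher number from compound 1 to compound 2 (0.16 log units; within the scatter). Compound 4 is therefore estimated at 5000 nM, with a likely range from 2500 nM to 10000 nM.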

Compound 4, inhibition constant: 3920 nM
Beside the measured number, compound 4's estimate is 1.3-fold (0.11 log units) above it, and the stated range covers the measured number.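

Methoxy in place of methyl, on an aromatic carbon para to a large group, gives a 1.1-fold higher number from compound 3 to compound 4 (0.04 log units; within the scatter) in this assay, so on this second core the change again stays within the scatter. The steps on the two cores agree: the same change on two cores in this assay, a 1.4-fold higher number (0.16 log units; within the scatter) from compound 1 to compound 2 and a 1.1-fold higher number (0.04 log units; within the scatter) from compound 3 to compound 4, 1.3-fold (0.11 log units) apart, within the scatter of two such steps

Going by these compounds alone, this shows only that a change too small to read on one core stays too small to read on the other; it does not show that a step of real size would carry across, and two pairs set no rule for further cores.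

Going by these compounds, it remains open whether an amine, a carboxylic acid or a longer chain in place of methyl would move the number beyond the scatter on either core. On these data alone, what the difference between the two cores contributes by itself also remains open.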